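Swapping a bulky dialkylamine for piperazine on the sulfonamide

The compounds below may be only part of what the source reports. "The series", "measured", "known", "first", "only" and "open" are said of these compounds alone.

Measured compounds:
compound 1, `CCC(C)N(C(C)CC)S(=O)(=O)c1ccc(NC(=O)C(C)(O)C(F)(F)F)cc1`: > 30000 nM
compound 2, `CC(O)(C(=O)Nc1ccc(Sc2ccccc2)cc1)C(F)(F)F`: > 30000 nM

In an assay on a protein complex (Cavia porcellus) with sulfonylurea receptors; K-ATP channels (Homo sapiens) as the target (a lower number here means a stronger inhibitor, a higher number a weaker inhibitor), compound 1 gives > 30000 nM, which is a limit of the assay rather than a number. Compound 2 likewise stops at > 30000 nM, again a limit. Both values sit at the limit of > 30000 nM in this assay, at which 2 of the 2 values shown sit, so compound 1 cannot be ranked against anything measured here. Compound 3 `CC(O)(C(=O)Nc1ccc(S(=O)(=O)N2CCNCC2)cc1)C(F)(F)F` differs from compound 1 by piperazin-1-yl in place of bis(sec-butyl)amino on a sulfonyl sulfur. Going by the values given here, no step between measured compounds exists, so the effect of this change cannot be read from the data. Compound 3 is therefore expected near the same limit, estimated at 40000 nM within 8000 nM to 200000 nM. This expectation corresponds to a step that the limit leaves unreadable from compound 1 to compound 3.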

Compound 3, half-maximal inhibitory concentration: > 30000 nM
Compound 3 gave a limit, no number; the forecaster's own chance of this, stated with the estimate: 75%; the middle value is on the limit's open side.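

Compound 1 and compound 3 both stop at a limit of the assay rather than a number, so no step can be read between them: the limit of > 30000 nM in this assay, at which 3 of the 3 values shown sit. The compounds shown leave open which change, if any, would give a measurable value.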